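The source may hold more compounds than are shown below. What is called first, only, known or untested is meant among the compounds shown, and "the series" means these compounds.

Compound 1 `Cc1ccc2c(c1NS(C)(=O)=O)CCC2c1ncc[nH]1`: > 10000 nM
Compound 2 `CCS(=O)(=O)Nc1cccc2c1CCC2c1ncc[nH]1`: > 10000 nM
Compound 3 `Clc1ccc2c(c1-c1ccn[nH]1)CCC2c1ncc[nH]1`: > 10000 nM

In a functional assay on CHO cells for agonist activity at Alpha-1B adrenergic receptor (Homo sapiens), read by FLIPR and calcium flux (a lower number here means that less compound is needed, a higher number that more compound is needed for the effect), compound 1 gives > 10000 nM, which is a limit of the assay rather than a number. Compound 2 gives > 10000 nM in this assay, again only a limit. Compound 3 gives > 10000 nM, also a limit. Compound 2 therefore stands with the others at the limit of > 10000 nM in this assay, at which 3 of the 3 values shown sit, so no measured number exists among these three compounds.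

Compound 4 `Cn1ccc(-c2cccc3c2CCC3c2ncc[nH]2)n1` differs from compound 2 in one place: 1-methyl-1H-pyrazol-3-yl in place of (ethylsulfonyl)amino on an aromatic carbon. For the measured compounds named here, no measured step between compounds is available to guide the size of this change. Since all three values sit at the limit, the step from compound 2 to compound 4 is expected to be a step that the limit leaves unreadable from compound 2 to compound 4, with no move beyond the scatter. Compound 4 is expected at 15000 nM, in the range 3000 nM to 60000 nM, most likely reported again only as a limit.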

Compound 4, half-maximal effective concentration: > 10000 nM
Compound 4 gave a limit, no number (the forecaster's own chance of this, stated with the estimate: 75%); the middle value is on the limit's open side.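

For the compounds shown here, compound 2 and compound 4 each give only a limit in this assay, so no step between them can be read. The compounds shown leave open whether 1-methyl-1H-pyrazol-3-yl in place of (ethylsulfonyl)amino changes the concentration needed for the effect at all.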